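The source may report more compounds than this note shows. Statements on the series, on what has been measured and on what is new or still open speak of the compounds shown alone.

In a functional assay on the whole organism (strain albino) for inhibition, with Rattus norvegicus as the target, read by paw edema, with stated times of 1 h and 2 h, at a dose of 100 mg/kg by the oral route (on this read-out lower numbers stand for less inhibition and higher numbers for more inhibition at the one dose given (going by the name of the read-out)), compound 2 `N#Cc1c(Cl)nc(SCC(=O)Nn2c(COc3ccc(Cl)cc3Cl)nc3ccccc3c2=O)nc1-c1ccc(O)cc1` gives 73.7%, and compound 1 `N#Cc1c(Cl)nc(SCC(=O)Nn2c(COc3ccc(Cl)cc3Cl)nc3ccccc3c2=O)nc1-c1ccc(Cl)cc1` gives 68.4%, the two within the usual scatter of each other. Among the compounds with values here, the only measured step, a number 5.3 percentage points higher from compound 1 to compound 2 (within the scatter), came from hydroxy in place of chloro on an aromatic carbon. Compound 3 `N#Cc1c(Nc2ccc(O)cc2)nc(SCC(=O)Nn2c(COc3ccc(Cl)cc3Cl)nc3ccccc3c2=O)nc1-c1ccc(O)cc1` differs from compound 2 by (4-hydroxyphenyl)amino in place of chloro on an aromatic carbon. Within the data shown here, no measured step swaps a chloro for a group of this kind, so the one step bearing on it only loosely is the small one from compound 1 to compound 2. Compound 3 is therefore expected to show no step beyond the scatter, a number 1.7 percentage points lower from compound 2 to compound 3 (within the scatter), and its estimated value in this assay is 72%, between 58% and 84%.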

Compound 3, a percentage reported as inhibition, in the whole organism at one dose (the size of the read-out at that dose, not a potency): 86.8%
Compound 3: the middle estimate sits 14.8 percentage points below what was measured; the whole stated range lies below it.
By their numbers in this assay, from the lowest: compounds 1 and 2 (each within the scatter of the next); then compound 3.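

In this assay, putting (4-hydroxyphenyl)amino in place of chloro, on the carbon next to the ring nitrogen and ortho to a cyano group, gives a number 13.1 percentage points higher from compound 2 to compound 3 (beyond the scatter). This is the first change shown to move the read-out beyond the scatter, and it shows that this position accepts a far larger group than chloro with no loss of inhibition at this dose. Nothing available explains the rise.

The compounds shown do not separate the part played by the amine link from that of the ring hydroxy. A plain anilino group, a methoxy on that ring or a morpholine at this carbon would bear on that question.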